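A few compounds are considered here, and "the series" means these few. Any claim that something is new, unique, unknown or untested is made for them only; others in the source may bear on it.

For the measured compounds named here, compound 1 `Cc1ccc(NC(=O)c2ccc(C)c(C(F)(F)F)c2)cc1OC1CCN(C(=O)c2cccnc2)CC1` gives 5470 nM in an ADME assay on BaF3 cells (Mus musculus) for antiproliferative activity (a lower number here means a stronger inhibitor of growth, a higher number a weaker inhibitor of growth), the only plain number in the set so far. Compound 2 `Cc1ccc(NC(=O)c2ccc(C)c(C(F)(F)F)c2)cc1OC1CCN(C(=O)c2cncs2)CC1` sits at the limit of > 10000 nM in this assay, at which 1 of the 2 values shown sits, reported in this assay as > 10000 nM, a limit rather than a number. The step of an at least 1.8-fold higher number from compound 1 to compound 2 (0.26 log units; that floor lies within the scatter) concerns a different carbonyl carbon. Compound 3 `COc1cccc(C(=O)Nc2ccc(C)c(OC3CCN(C(=O)c4cccnc4)CC3)c2)c1` changes the amide on the other side: 3-methoxyphenyl in place of 4-methyl-3-(trifluoromethyl)phenyl on a carbonyl carbon. Going by the values given here, no measured step covers this exchange, and the single step on record is itself only a floor, so the expectation rests on compound 1 alone. The expected change is a 2.2-fold higher number from compound 1 to compound 3 (0.34 log units; beyond the scatter), with a real chance of reaching the limit. Compound 3 is estimated at 12000 nM, range 4000 nM to 40000 nM.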

Compound 3, concentration for 50% growth inhibition: > 10000 nM
Compound 3: only a limit was reported; the forecaster's own chance of this, stated with the estimate: 55%; the middle value lies beyond the limit too.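

In this assay, the exchange of 4-methyl-3-(trifluoromethyl)phenyl for 3-methoxyphenyl on this carbonyl carbon gives an at least 1.8-fold higher number from compound 1 to compound 3 (0.26 log units; that floor lies within the scatter), so a loss is not established and its size cannot be read. Compound 3 gives > 10000 nM, which is a limit and not a number. Changes on both carbonyl carbons have now ended at the limit, leaving compound 1 as the only plain number: the limit of > 10000 nM in this assay, at which 2 of the 3 values shown sit.

As far as these compounds go, the true sizes of both steps remain open. Also open, from the compounds shown here alone, is whether an amine or a carboxylic acid on the phenyl ring at this carbonyl carbon would give a plain number.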